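A Second Hydroxyl on the Chain of a Brominated Core

The source may report more compounds than this note shows. Statements on the series, on what has been measured and on what is new or still open speak of the compounds shown alone.

Two compounds share a tetrabrominated core carrying a short chain on a ring nitrogen. Compound 1 `COc1cccc(C(O)CCn2nc3c(Br)c(Br)c(Br)c(Br)c3n2)c1` bears a longer, bulkier chain; compound 2 `C[C@@H](O)CCn1nc2c(Br)c(Br)c(Br)c(Br)c2n1` carries the shorter 3-hydroxybutyl chain. In a functional assay on CCRF-CEM cells (Homo sapiens) for antiproliferative activity, read by MTT assay, with a stated time of 48 h, tested at 25 uM (on this read-out higher numbers stand for a weaker effect at the one concentration tested and lower numbers for a stronger effect), compound 1 gives 50%, while compound 2 gives 71%, the higher of the two numbers, so compound 2 shows the weaker effect, and the gap between them lies beyond the scatter.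

Compound 3 `OCC(O)Cn1nc2c(Br)c(Br)c(Br)c(Br)c2n1` differs from compound 2 in one place: 1,2-dihydroxyethyl in place of 2-hydroxypropyl on a saturated chain carbon bound to an aromatic nitrogen. Among the measured compounds shown here, no pair of measured compounds shows a change of this kind, so there is no measured step to lean on. Because compound 2 already gives 71%, the expected step to compound 3 is small and, if anything, toward a higher number, as a number 5 percentage points higher from compound 2 to compound 3 (within the scatter). Compound 3 is therefore estimated at 76%, within 56% to 96%.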

Compound 3, a percentage reported as activity, at one concentration (the size of the read-out at that concentration, not a potency): 56%
Estimate against measurement, compound 3: 20 percentage points above, and the stated range covers the measured number.
By their numbers in this assay, from the lowest: compounds 1 and 3 (each within the scatter of the next); then compound 2.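

In this assay, putting 1,2-dihydroxyethyl in place of 2-hydroxypropyl on a saturated chain carbon bound to an aromatic nitrogen gives a number 15 percentage points lower from compound 2 to compound 3 (beyond the scatter), which means a stronger effect. Among the compounds shown here, this is the first measured step at this place on the chain, and it shows that a second hydroxyl, with the heavy-atom count unchanged, strengthens the effect in this pair rather than leaving it flat or weakening it. Nothing in the data shown explains why the number moves.

The change also removes the defined stereocentre of compound 2, so this one step cannot separate the second hydroxyl from the loss of that stereocentre. As far as these compounds go, it also remains open whether an amine or a carboxylic acid in place of the second hydroxyl would keep this effect.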